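A few compounds are considered here, and "the series" means these few. Any claim that something is new, unique, unknown or untested is made for them only; others in the source may bear on it.

Compound 1 `CN(C)C(=O)c1cc2cnc(Nc3ccc(NC(=O)C4(C(=O)Nc5cccc(F)c5)CC4)cc3)nc2n1C1CCCC1`: 107%
Compound 2 `CN(C)C(=O)c1cc2cnc(Nc3ccc(NC(=O)C4(C(=O)Nc5ccc(Br)cc5)CC4)cc3)nc2n1C1CCCC1`: 98.8%

In a functional assay on SiHa cells (Homo sapiens) for inhibition, read by CCK-8 assay, with a stated time of 72 h, tested at 10 uM (a higher number here means more inhibition of growth at the concentration tested, a lower number less inhibition of growth), compound 2 gives 98.8%, which cannot be told apart from compound 1: a number 8.2 percentage points lower from compound 1 to compound 2 (within the scatter). Among the compounds with values here, the next compound, compound 3 `CN(C)C(=O)c1cc2cnc(Nc3ccc(NC(=O)C4(C(=O)Nc5ccc(Cl)c(C(F)(F)F)c5)CC4)cc3)nc2n1C1CCCC1`, keeps the shared core and alters only one group: 4-chloro-3-(trifluoromethyl)phenyl in place of 4-bromophenyl on an amide-type nitrogen. Put simply, 4-chloro-3-(trifluoromethyl)phenyl comes in place of 4-bromophenyl on an amide-type nitrogen. Within the data shown here, only one measured step bears on this, the one between compound 1 and compound 2, made at the same place, and its size stayed within the scatter. Among the measured compounds shown here, a single step is thin evidence, and no measured compound carries this new group. Even so, no shift beyond the scatter is expected in either direction, so the expected change is a number 1.8 percentage points lower from compound 2 to compound 3 (within the scatter). Compound 3 is estimated at 97%, with an expected range of 82% to 110%.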

Compound 3, percent growth inhibition at one concentration: 61.1%
The estimate for compound 3 lay 35.9 percentage points above the measured number; the whole stated range lies above it.
By their numbers in this assay, from the lowest: compound 3; then compounds 2 and 1 (each within the scatter of the next).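

In this assay, placing 4-chloro-3-(trifluoromethyl)phenyl on the amide-type nitrogen gives a number 37.7 percentage points lower from compound 2 to compound 3 (beyond the scatter) and a number 45.9 percentage points lower from compound 1 to compound 3 (beyond the scatter), so this position is not indifferent to the group it carries. The earlier exchange of 3-fluorophenyl for 4-bromophenyl stayed within the scatter and gave no hint of this: some substituted phenyl groups here leave the growth inhibition unchanged, but this one does not. Nothing measured here explains the loss.

The new group brings chlorine and trifluoromethyl together, so the compounds shown cannot say whether one of them alone accounts for the step; a phenyl ring carrying only a chlorine or only a trifluoromethyl would separate the two. Also open, as far as these compounds go, is how a ring that is not a substituted phenyl, such as a pyridine or a cyclohexyl, would behave at this position.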